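Cytotoxicity in the aminopyrimidine nitrile series, compound 3 to 4

A few compounds are considered here, and "the series" means these few. Any claim that something is new, unique, unknown or untested is made for them only; others in the source may bear on it.

Measured so far:
- compound 1 `N#Cc1ccc(Nc2nccc(OC3CCCCC3)n2)cc1`: 322000 nM
- compound 2 `N#Cc1ccc(Nc2nccc(OC3CCCC3)n2)cc1`: >= 339000 nM
- compound 3 `Cc1cnc(Nc2ccc(C#N)cc2)nc1NC1CCCC1`: 170 nM

In an ADME assay on MT4 cells (Homo sapiens) for cytotoxicity, read by MTT assay (on this read-out lower numbers stand for higher toxicity in this test and higher numbers for lower toxicity in this test), compound 1 gives 322000 nM. For compound 2 the value of >= 339000 nM is a limit of this assay, not a number. Compound 3 holds the lowest number in this assay, and its nearest measured neighbour, compound 1, stands much higher. Going by the values given here, the only measured step, an at least 1.0-fold higher number from compound 1 to compound 2 (0.02 log units; that floor lies within the scatter), concerns the ring on the oxygen and not the change at hand.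

Compound 4 `N#Cc1ccc(Nc2nccc(NC3CCCC3)n2)cc1` differs from compound 3 by hydrogen in place of methyl on an aromatic carbon. Among the compounds with values here, no measured step bears on this change, so the expectation rests only on compound 3 with 170 nM and on the wide spread across the series. For compound 4 a number near 3000 nM is expected, within 200 nM to 100000 nM, meaning an estimated step of an 18-fold higher number from compound 3 to compound 4 (1.25 log units; beyond the scatter).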

Compound 4, half-maximal cytotoxic concentration: 9130 nM
Compound 4: middle estimate off by 3.0-fold (0.48 log units), on the low side; measured number inside the range.
By their numbers in this assay, from the lowest: compound 3; then compound 4; then compound 1. At a limit, above all of these: compound 2.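

Notes on the series: in this assay, hydrogen in place of methyl on this aromatic carbon, ortho to a cyclopentylamino group, gives a 54-fold higher number from compound 3 to compound 4 (1.73 log units; beyond the scatter), so this single position moves the number strongly. The group on the neighbouring substituent site matters too: cyclopentylamino in place of cyclohexyloxy gives a 35-fold lower number from compound 1 to compound 4 (1.55 log units; beyond the scatter). Compound 2 holds a limit, so cyclopentylamino in place of cyclopentyloxy gives only a floor, an at least 37-fold lower number from compound 2 to compound 4 (1.56 log units; beyond the scatter), and it rests on this: the limit of >= 339000 nM in this assay, at which 1 of the 4 values shown sits.

On these data alone, whether ethyl or chlorine on this carbon behaves like methyl remains open. So does whether methyl there lowers the number with cyclopentyloxy in place of cyclopentylamino.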